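Phenyl to pyridin-4-yl on compound 2

The source may hold more compounds than are shown below. What is called first, only, known or untested is meant among the compounds shown, and "the series" means these compounds.

Measured so far in a physicochemical assay for solubility; on this read-out higher numbers stand for higher solubility and lower numbers for lower solubility:
Compound 1 `C[C@H]1C(=O)N(C)C=Cc2cc(C(CO)CO)ccc21`: >= 209 ug/mL
Compound 2 `CCS(=O)(=O)c1ccc2c(c1)C(c1ccccc1)=CN(C)C(=O)C2C`: >= 146 ug/mL

Compound 2 stands only at a limit of the assay, >= 146 ug/mL, and not at a number. The entry for compound 1, >= 209 ug/mL, is likewise a limit.

The next compound is compound 3 `CCS(=O)(=O)c1ccc2c(c1)C(c1ccncc1)=CN(C)C(=O)C2C`, which differs from compound 2 in one place: pyridin-4-yl in place of phenyl on a double-bonded ring carbon. It carries pyridin-4-yl in place of phenyl on a double-bonded ring carbon of a seven-membered non-aromatic ring. Going by the values given here, no measured pair shows a step of this kind. The size of the step therefore rests on expectation alone. A small rise in this assay is expected, possibly none beyond the usual scatter. The estimated step is a step that the limit leaves unreadable from compound 2 to compound 3. Compound 3 may be expected to report only a limit as well, as compound 2 does at >= 146 ug/mL. For compound 3 the estimated value is 190 ug/mL, with an expected range from 130 ug/mL to 300 ug/mL.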

Compound 3, solubility: 128 ug/mL
Compound 3: the middle estimate sits 1.5-fold (0.17 log units) above what was measured; measured number below the stated range.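

Compound 3 gives the first number rather than a limit among the compounds shown in this assay, so a substituent on this double-bonded ring carbon of the seven-membered ring now has a readable value. Pyridin-4-yl in place of phenyl gives an at least 1.1-fold lower number from compound 2 to compound 3 (0.05 log units; that floor lies within the scatter), so the data offer no sign of a rise with this change, against nothing firmer than a floor on the step. The full size of the step cannot be read, because compound 2 stands at a limit of the assay and not at a number: the limit of >= 146 ug/mL in this assay, at which 1 of the 3 values shown sits.

On these data alone, whether a number for compound 2 would carry this step beyond the usual scatter stays open, and one change at one position sets no trend for the series. Also open, as far as these compounds go, is how an aminomethyl or a carboxylic acid on the pyridin-4-yl ring, or a pyridin-3-yl group on the same double-bonded ring carbon, would read in this assay against compound 3.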